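The source may report more compounds than this note shows. Statements on the series, on what has been measured and on what is new or still open speak of the compounds shown alone.

Compound 1 `CCOC(=O)c1cc(/C=N/Nc2ccc(C(C)C)cc2)c(O)c(/C=N/Nc2ccc(C(C)C)cc2)c1`: 29700 nM
Compound 2 `O=C(O)c1cccc(N/N=C/c2cc(C(=O)NCCCc3ccccc3)c3ccccc3n2)c1`: 64300 nM

In an ADME assay on BHK cells (Mesocricetus auratus) for cytotoxicity, read by MTT assay, with a stated time of 48 h (on this read-out higher numbers stand for lower toxicity in this test and lower numbers for higher toxicity in this test), compound 2 gives 64300 nM, the higher of the two numbers and so the lower toxicity in this test. Compound 1 gives 29700 nM, and this gap lies beyond the usual scatter of repeated measurements.

Compound 3 `O=C(O)c1cccc(N/N=C/c2cc(C(=O)NCCCCc3ccccc3)c3ccccc3n2)c1` differs from compound 2 in one place: benzyl in place of phenyl on a saturated chain carbon, three bonds along the chain from an amide-type nitrogen. This is benzyl in place of phenyl on a saturated chain carbon, three bonds along the chain from an amide-type nitrogen. Cut one bond further out, it reads 3-phenylpropyl to 4-phenylbutyl.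

Among the compounds with values here, no pair of measured compounds shows what such a change does in this assay, so any expectation here is cautious. The expected step of a 1.2-fold lower number from compound 2 to compound 3 (0.07 log units; within the scatter) is small, with no shift beyond the scatter. For compound 3 the estimated value is 55000 nM, with an expected range from 25000 nM to 110000 nM.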

Compound 3, half-maximal cytotoxic concentration: 49700 nM
For compound 3 the middle estimate is 1.1-fold (0.04 log units) above the measured one, and the stated range covers the measured number.
By their numbers in this assay, from the lowest: compounds 1, 3 and 2 (each within the scatter of the next, the first and the last beyond it).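

In this assay, the change from 3-phenylpropyl to 4-phenylbutyl gives a 1.3-fold lower number from compound 2 to compound 3 (0.11 log units; within the scatter), so this single added chain carbon leaves no reading that can be told apart from repeat scatter. Within the data shown here, this is the first view of this position, on a saturated chain carbon, three bonds along the chain from an amide-type nitrogen, and for this one pair the cell toxicity reading holds steady when benzyl stands in place of phenyl. Nothing available here points to a reason for this result.

One step cannot show whether a shorter phenethyl chain or a longer 5-phenylpentyl chain would stay as close to these compounds. As far as these compounds go, how an amine at the end of the chain, in place of the phenyl ring, would read in this test also remains open.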